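A few compounds are considered here, and "the series" means these few. Any claim that something is new, unique, unknown or untested is made for them only; others in the source may bear on it.

Series notes, values from a functional assay on DU-145 cells (Homo sapiens) for antiproliferative activity, read by MTT assay, with a stated time of 48 h; a higher number here means a weaker inhibitor, a lower number a stronger inhibitor:

- compound 1 `COc1ccc(/C=C/C(=O)c2cc(OC)c(OC)c(OC)c2)cc1OCCCC(=O)NCCCNCCCCNCCN`: 28500 nM
- compound 2 `COc1cc(C(=O)/C=C/c2ccc(OCCCC(=O)NCCCNCCCCN)cc2)cc(OC)c1OC`: > 100000 nM (a limit)
- compound 3 `COc1cc(C(=O)/C=C/c2ccc(OCCCC(=O)NCCCNCCCCNCCN)cc2)cc(OC)c1OC`: 35400 nM

Compound 1 at 28500 nM and compound 3 at 35400 nM lie within the scatter of each other. Compound 2 gives no number, only a limit.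

Not yet measured is compound 4 `COc1ccc(/C=C/C(=O)c2cc(OC)c(OC)c(OC)c2)cc1OCCCC(=O)NCCCCNCCCN`. The change from compound 1 is ((3-aminopropyl)amino)methyl in place of (4-((2-aminoethyl)amino)butyl)amino on a saturated chain carbon, three bonds along the chain from an amide-type nitrogen.

Going by the values given here, one measured step bears on this: an at least 2.8-fold lower number from compound 2 to compound 3 (0.45 log units; beyond the scatter), with 2-aminoethyl in place of hydrogen on an amine nitrogen. That step was measured on the core of compound 3, not the core of compound 1, and compound 4 also orders its chain differently, so it is only a partial guide. Compound 4 lacks the 2-aminoethyl end, so a higher number of similar size, beyond the scatter, is expected in this assay. The estimated step is a 2.5-fold higher number from compound 1 to compound 4 (0.39 log units; beyond the scatter). Compound 4 is expected at 70000 nM, with an estimated range of 30000 nM to 150000 nM.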

Compound 4, half-maximal inhibitory concentration in the DU-145 assay: 99300 nM
Compound 4: the middle estimate sits 1.4-fold (0.15 log units) below what was measured, within the range that was stated.
By their numbers in the DU-145 assay, from the lowest: compounds 1 and 3 (each within the scatter of the next); then compound 4. At a limit, above all of these: compound 2.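

In the DU-145 assay compound 1 gives 28500 nM and compound 4 gives 99300 nM, which is a 3.5-fold higher number from compound 1 to compound 4 (0.54 log units; beyond the scatter). This shows that the change to ((3-aminopropyl)amino)methyl on a saturated chain carbon, three bonds along the chain from an amide-type nitrogen, costs activity on the core of compound 1 itself, whereas the earlier step was read on the core of compound 3. In a physicochemical assay for lipophilicity, read by spectrophotometry, measured as octanol-water partition, tested at 300 uM (on this read-out lower numbers stand for lower lipophilicity and higher numbers for higher lipophilicity), compound 1 gives -1.57 and compound 4 gives -1.28, which is a number 0.29 log units higher from compound 1 to compound 4 (within the scatter), so this loss of activity comes without a partition change beyond the scatter.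

Going by these compounds alone, still open is whether the loss follows the missing 2-aminoethyl end, the shorter chain or the changed order of its amines, as the single change alters all of these together. A longer chain, with a 2-aminoethyl group added to the terminal amine of compound 4, would separate the end group from the chain order.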